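Trifluoromethyl on the Anilide Ring: Expected Cytotoxicity

A few compounds are considered here, and "the series" means these few. Any claim that something is new, unique, unknown or untested is made for them only; others in the source may bear on it.

Measured so far:
Compound 1 `CN(C(=O)C1(c2ccccc2)CCCC1)c1ccccc1`: 52000 nM
Compound 2 `CN(C(=O)C1(c2ccc(Cl)cc2)CCCC1)c1ccccc1`: 21000 nM

In an ADME assay on MDCK cells (Canis lupus familiaris) for cytotoxicity (on this read-out higher numbers stand for lower toxicity in this test and lower numbers for higher toxicity in this test), compound 1 gives 52000 nM, the highest of the two numbers; the nearest is compound 2 with 21000 nM. Compound 3 `CN(C(=O)C1(c2ccccc2)CCCC1)c1ccc(C(F)(F)F)cc1` differs from compound 1 by trifluoromethyl in place of hydrogen on an aromatic carbon. Among the compounds with values here, the only measured step, a 2.5-fold lower number from compound 1 to compound 2 (0.39 log units; beyond the scatter), added a substituent to the other aromatic ring, so it bears only loosely on this change; it suggests that a new group on an aromatic carbon may lower the number modestly. A modest drop is therefore expected in this assay. Compound 3 is estimated at 30000 nM, with a range from 12000 nM to 80000 nM. This estimate means an expected step of a 1.7-fold lower number from compound 1 to compound 3 (0.24 log units; within the scatter).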

Compound 3, half-maximal cytotoxic concentration: 21000 nM
The estimate for compound 3 lay 1.4-fold (0.15 log units) above the measured number; the range from low to high includes it.
By their numbers in this assay, from the lowest: compounds 2 and 3 (each within the scatter of the next); then compound 1.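

In this assay adding trifluoromethyl para to a large group gives a 2.5-fold lower number from compound 1 to compound 3 (0.39 log units; beyond the scatter) and so moves the result toward higher toxicity in this test. This shows that the position responds to substitution, which compound 2 could not show with its change on the other aromatic ring. No evidence is available to explain this drop. From the compounds shown here alone, it remains open whether an amine or a carboxylic acid at this position would shift the number the same way. A single methoxy group here would also help show whether any added group lowers it.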